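A Carbonyl Substituent Swap on Compound 1

This account rests on a few compounds, and the source may have more. Where it says the series, first, only, none or still open, it means among the compounds named here.

Of the compounds shown here, two have been measured in a functional assay on HCT-116 cells (Homo sapiens) for inhibition, read by MTT assay, with a stated time of 2 days, tested at 10 uM; a lower number here means less inhibition, a higher number more inhibition at the concentration tested (going by the name of the read-out). Compound 1 `COc1ccc(-c2cn(-c3ccc(O)c(C(=O)Nc4cccc(C(F)(F)F)c4)c3)nn2)cc1` gives 9%, the lower of the two numbers. Within the data shown here, compound 2 `COc1cc(OC)cc(-c2cn(-c3ccc(O)c(C(=O)Nc4cccc(C(F)(F)F)c4)c3)nn2)c1` gives 62% in this assay, and the only measured step, a number 53 percentage points higher from compound 1 to compound 2 (beyond the scatter), comes from a change on an aromatic carbon far from the carbonyl. Compound 3 `COc1ccc(-c2cn(-c3ccc(O)c(C(=O)OCCCc4ccccc4)c3)nn2)cc1` has not been measured yet. It differs from compound 1 in one place: 3-phenylpropoxy in place of (3-(trifluoromethyl)phenyl)amino on a carbonyl carbon. Among the measured compounds shown here, no measured step touches this carbonyl position, so the step from compound 1 to compound 2 does not speak to the change in question; the only anchor for compound 3 is the value of compound 1 itself. Because compound 1 sits at 9%, with nothing to show that this part of the molecule moves the read-out, the expected step of a number 6 percentage points higher from compound 1 to compound 3 (within the scatter) is small, and a change of either direction within the scatter would not surprise. Compound 3 is therefore estimated at 15%, with a plausible range from 0% to 45%.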

Compound 3, a percentage reported as inhibition, at one concentration (the size of the read-out at that concentration, not a potency): 12%
Estimate against measurement, compound 3: 3 percentage points above; measured number inside the range.
By their numbers in this assay, from the lowest: compounds 1 and 3 (each within the scatter of the next); then compound 2.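

In this assay, among these compounds, the first measured change on this carbonyl carbon gives a number 3 percentage points higher from compound 1 to compound 3 (within the scatter) and so leaves compound 1 and compound 3 indistinguishable, even though the swap replaces the whole (3-(trifluoromethyl)phenyl)amino group with 3-phenylpropoxy. The group that leaves has 1 hydrogen-bond donor and 0 hydrogen-bond acceptors, and the group that enters has 0 donors and 1 acceptor, so on the 4-methoxyphenyl background this exchange comes with no step beyond the scatter, while both compounds stay low in the read-out. Among the compounds shown here, nothing measured here explains this outcome, and it shows only that this one pair matches, not that the position never matters.

As far as these compounds go, with both numbers this low, the pair has little room to reveal a loss, so it remains open whether 3-phenylpropoxy would match (3-(trifluoromethyl)phenyl)amino on the 3,5-dimethoxyphenyl background of compound 2, where the read-out is much higher. The compounds shown also leave open what other groups on this carbonyl carbon would give, such as a carboxylic acid, a benzylamino group or a shorter benzyloxy chain.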